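This account rests on a few compounds, and the source may have more. Where it says the series, first, only, none or still open, it means among the compounds named here.

The series shares one core and varies the group on a saturated chain carbon bound to an amine nitrogen in a ring, all tested in a functional assay on the whole organism for antagonist activity, with Mus musculus as the target; a lower number here means that less compound is needed, a higher number that more compound is needed for the effect. Compound 1 `CCCCCCCN1CCC(C(=O)Nc2cc(Cl)c(N)cc2OC)CC1` carries hexyl there; in this assay compound 1 gives > 10 mg/kg, which is a limit of the assay rather than a number. Compound 2 `COc1cc(N)c(Cl)cc1NC(=O)C1CCN(Cc2ccccc2)CC1` carries phenyl, and in this assay compound 2 gives 0.5 mg/kg. Compound 3 `COc1cc(N)c(Cl)cc1NC(=O)C1CCN(Cc2ccc([N+](=O)[O-])cc2)CC1` carries 4-nitrophenyl; in this assay compound 3 gives > 4 mg/kg, again a limit and not a number. Compound 3 thus stands at the limit of > 4 mg/kg in this assay, at which 1 of the 3 values shown sits, among the compounds that reached no measurable dose. The step of an at least 8.0-fold higher number from compound 2 to compound 3 (0.90 log units; beyond the scatter) shows the nitro group costing activity, while the step of an at least 20-fold lower number from compound 1 to compound 2 (1.30 log units; beyond the scatter) shows a six-membered aromatic ring working far better than the hexyl chain in this place. Compound 4 `COc1cc(N)c(Cl)cc1NC(=O)C1CCN(Cc2ccsc2)CC1` is not yet measured. The change is thiophen-3-yl in place of 4-nitrophenyl on a saturated chain carbon bound to an amine nitrogen in a ring. Since thiophen-3-yl is a five-membered aromatic ring lacking the nitro group, compound 4 is expected to move back toward compound 2, which gave 0.5 mg/kg. The step is expected as an at least 4.0-fold lower number from compound 3 to compound 4 (0.60 log units; beyond the scatter), toward a lower number, though its size cannot be read against the limit of compound 3. Compound 4 is therefore estimated at 1 mg/kg, within 0.3 mg/kg to 4 mg/kg.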

Compound 4, dose for half-maximal effect: 3.4 mg/kg
Beside the measured number, compound 4's estimate is 3.4-fold (0.53 log units) below it; the measured number falls inside the stated range.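

At the place on a saturated chain carbon bound to an amine nitrogen in a ring, a five-membered aromatic ring now has a measured value in this assay, and thiophen-3-yl in place of phenyl gives a 6.8-fold higher number from compound 2 to compound 4 (0.83 log units; beyond the scatter), so an aromatic ring as such does not hold the level set by phenyl. Thiophen-3-yl in place of hexyl still gives an at least 2.9-fold lower number from compound 1 to compound 4 (0.46 log units; beyond the scatter), so the advantage over the hexyl chain, so far shown only for phenyl, also appears with this second aromatic ring, though less far than with phenyl. The comparison with 4-nitrophenyl rests on a limit of the assay, and thiophen-3-yl in its place gives only an at least 1.1-fold lower number from compound 3 to compound 4 (0.07 log units; that floor lies within the scatter), a floor that supports no claim of a gain: the limit of > 4 mg/kg in this assay, at which 1 of the 4 values shown sits.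

The compounds shown cannot separate the size of the ring from the presence of the sulfur atom in the loss against phenyl, and a furan-3-yl or pyridin-3-yl group at this place would bear on that. It also remains open whether the phenyl ring tolerates any substituent, since nitro is the only one shown, and a 4-methoxyphenyl or 4-chlorophenyl group would test this.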